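A few compounds are considered here, and "the series" means these few. Any claim that something is new, unique, unknown or untested is made for them only; others in the source may bear on it.

Working notes on the amidine series. Compound 1 `CC1=COC(N)=N[C@]1(C)c1cc(NC(=O)c2ccc(C#N)cn2)ccc1F` and compound 2 `C[C@@]1(c2cc(NC(=O)c3cnc(OCF)cn3)ccc2F)C=C(CF)OC(N)=N1` share the amide link and differ in both the aryl amide and the core. In a physicochemical assay for lipophilicity, read by HPLC, in phosphate buffer, measured as octanol-water partition, with a stated time of 1 h, at pH 7.4 (on this read-out lower numbers stand for lower lipophilicity and higher numbers for higher lipophilicity), compound 1 gives 1.5, and compound 2 gives 2.6, the higher of the two numbers, with the gap to compound 1 beyond the scatter. Among the measured compounds shown here, no step between compounds that differ in one place is available, so the two values are simply noted side by side.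

Compound 3 `C[C@@]1(c2cc(NC(=O)c3ccc(C#N)cn3)ccc2F)C=C(CF)OC(N)=N1` is not yet measured in this assay. Against compound 2 it differs in one place: 5-cyanopyridin-2-yl in place of 5-(fluoromethoxy)pyrazin-2-yl on a carbonyl carbon. Compound 1 carries the same 5-cyanopyridin-2-yl amide on a different core and sits well below compound 2, so compound 3 is expected to come in somewhat lower than compound 2, by a step of a number 0.40 log units lower from compound 2 to compound 3 (beyond the scatter) in this assay, a modest move that may not clear the scatter. The estimate for compound 3 in this assay is 2.2, with a range from 1.7 to 2.7.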

Compound 3, distribution coefficient: 2.3
The estimate for compound 3 lay 0.10 log units below the measured number, and the stated range covers the measured number.
By their numbers in this assay, from the lowest: compound 1; then compounds 3 and 2 (each within the scatter of the next).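

In this assay, 5-cyanopyridin-2-yl in place of 5-(fluoromethoxy)pyrazin-2-yl on a carbonyl carbon gives a number 0.30 log units lower from compound 2 to compound 3 (within the scatter), so the two groups cannot be told apart on this read-out at this position on the shared core. Among the compounds shown here, this is the first pair that differs in one place, whereas compound 1 and compound 2 differ in both the aryl amide and the core, which left their gap unassigned to either part. Nothing at hand bears on why these two groups read alike.

Going by these compounds, it remains open how a group carrying an amine or a carboxylic acid on the same carbonyl carbon would read against these two aromatic rings. Also open, on these data alone, is whether the same exchange would read alike on the core of compound 1.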